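The source may report more compounds than this note shows. Statements on the series, on what has been measured and on what is new or still open speak of the compounds shown alone.

Compound 1 `O=C(Nc1ccccc1C(F)(F)F)C1CCc2ccccc2N1C(=O)c1ccccc1` is one of three amides built on a shared core. In a functional assay on NUGC-3 cells (Homo sapiens) for cytotoxicity, read by sulforhodamine B assay, with a stated time of 72 h (on this read-out lower numbers stand for stronger inhibition of growth and higher numbers for weaker inhibition of growth), compound 1 gives 8120 nM, the highest of the two numbers recorded. Compound 3 `O=C(Nc1ccccc1O)C1CCc2ccccc2N1C(=O)c1ccccc1` gives 3780 nM, and the step of a 2.1-fold lower number from compound 1 to compound 3 (0.33 log units; beyond the scatter) is modest. Compound 2 `CC(=O)N1c2ccccc2CCC1C(=O)Nc1cc(C(F)(F)F)cc(C(F)(F)F)c1` reaches only a limit of the assay, giving > 70000 nM; this is the limit of > 70000 nM in this assay, at which 1 of the 3 values shown sits. Compound 4 `O=C(Nc1ccccc1C(F)(F)F)C1CCc2ccccc2N1` has not been measured; it differs from compound 1 by hydrogen in place of benzoyl on a nitrogen on an aromatic ring in a ring. Among the compounds with values here, no measured step touches this change, since the only step recorded alters a group on an aromatic carbon. The expectation therefore rests on compound 1 alone, with a wide range and a tilt toward a weaker number. Compound 4 is expected to give 20000 nM, between 5000 nM and 70000 nM, an expected step of a 2.5-fold higher number from compound 1 to compound 4 (0.39 log units; beyond the scatter).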

Compound 4, concentration for 50% growth inhibition: 39300 nM
Beside the measured number, compound 4's estimate is 2.0-fold (0.29 log units) below it; the range from low to high includes it.
By their numbers in this assay, from the lowest: compound 3; then compound 1; then compound 4. At a limit, above all of these: compound 2.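

In this assay, hydrogen in place of benzoyl on this nitrogen weakens growth inhibition, with a 4.8-fold higher number from compound 1 to compound 4 (0.68 log units; beyond the scatter), the first measured sign that this position affects the read-out. Compound 4 still gives a number rather than a limit of the assay, so some growth inhibition remains without the benzoyl. Nothing measured here explains the change.

Going by these compounds, on this nitrogen, only hydrogen and benzoyl can be compared with the rest of the compound held fixed, so a methyl or a methanesulfonyl group there remains open. On these data alone, whether the hydroxy of compound 3 would give a similar result without the benzoyl also remains open.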